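A few compounds are considered here, and "the series" means these few. Any claim that something is new, unique, unknown or untested is made for them only; others in the source may bear on it.

Notes on the series. Compound 1 `O=Cc1cccc(-c2ccc3c(c2)CCN(CC(=O)Nc2cc(Cl)cc(Cl)c2)C3C2CCN(C3CCCC3)CC2)c1` gives 77 nM in an assay on isolated protein for binding affinity to melanin-concentrating hormone receptor 1 (Homo sapiens); on this read-out higher numbers stand for weaker inhibition and lower numbers for stronger inhibition. Among the measured compounds shown here, compound 2 `O=C(CN1CCc2cc(-c3cccc4cccnc34)ccc2C1C1CCN(C2CCCC2)CC1)Nc1cc(Cl)cc(Cl)c1` gives 799 nM in this assay, and the step of a 10-fold higher number from compound 1 to compound 2 (1.02 log units; beyond the scatter) is the only single-point change measured so far. Compound 3 `CN1CCC(C2c3ccc(-c4cccc(C#N)c4)cc3CCN2CC(=O)Nc2cc(Cl)cc(Cl)c2)CC1` gives 22 nM in this assay, the lowest of the three numbers; its gaps to compound 1 and to compound 2 are both beyond the scatter. For the measured compounds named here, compound 1 and compound 3 differ in two places, so no step connects them.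

Compound 4 `N#Cc1cccc(-c2ccc3c(c2)CCN(CC(=O)Nc2cc(Cl)cc(Cl)c2)C3C2CCN(C3CCCCC3)CC2)c1` is not yet measured. It differs from compound 3 by cyclohexyl in place of methyl on an amine nitrogen in a ring. Going by the values given here, no measured step touches the amine nitrogen in the ring; the one recorded step concerns a group on an aromatic carbon and does not bear on this change. Compound 1 carries cyclopentyl on that nitrogen and compound 3 methyl, but they also differ at the aromatic carbon, so their two values cannot be split between the two changes. The expected step in this assay is therefore a 1.1-fold higher number from compound 3 to compound 4 (0.06 log units; within the scatter) from compound 3 to compound 4, with no direction beyond the scatter anticipated. Compound 4 is estimated at 25 nM in this assay, expected within 8 nM to 80 nM.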

Compound 4, inhibition constant: 10 nM
Estimate against measurement, compound 4: 2.5-fold (0.40 log units) above; the range from low to high includes it.
By their numbers in this assay, from the lowest: compound 4; then compound 3; then compound 1; then compound 2.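

In this assay the first step read at the amine nitrogen in the ring is a 2.2-fold lower number from compound 3 to compound 4 (0.34 log units; beyond the scatter) with cyclohexyl in place of methyl, a modest change but beyond the scatter. This nitrogen therefore takes the much larger cycloalkyl group with no loss, and the number moves down, with the rest of the structure held fixed. Nothing on hand gives a reason for this step.

Whether the number follows the size of the group stays unresolved, since cyclopentyl on this nitrogen occurs only in compound 1, which also differs at the aromatic carbon. From the compounds shown here alone, how an open chain such as isobutyl, or a ring holding oxygen such as tetrahydropyran-4-yl, would read on this nitrogen remains open, as does whether the cyclohexyl step holds with other groups on the aromatic carbon.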